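The source may report more compounds than this note shows. Statements on the series, on what has been measured and on what is new or still open speak of the compounds shown alone.

Compound 1, `Cc1ccn2c(C)c(C)nc2c1OCc1ccccc1`: 92%
Compound 2, `Cc1nc2c(OCc3ccccc3F)cccn2c1N`: 93%
Compound 3, `Cc1nc2ccc(CCc3ccccc3)cn2c1N`: 52%

Of the compounds shown here, three have been measured in a functional assay on the whole organism with Rattus norvegicus as the target, at a dose of 40 mg/kg by the intraperitoneal route; on this read-out lower numbers stand for less inhibition and higher numbers for more inhibition at the one dose given (going by the name of the read-out). Compound 1 gives 92%, and compound 2, with 93%, lies within the scatter of it, so the two cannot be told apart on this read-out. Compound 3, at 52%, stands well beyond the scatter below both. Compound 1 therefore sits among the higher numbers shown, level with compound 2 and clearly above compound 3.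

The unmeasured compound 4, `Cc1ccn2c(N)c(C)nc2c1OCc1ccccc1`, is compound 1 with one change: amino in place of methyl on an aromatic carbon. For the measured compounds named here, no single-place step between measured compounds exists to calibrate this change, so any expectation rests on the read-out of compound 1 itself and on the fact that compound 2, which also carries an amino group on its core, gives 93%. In this assay the step from compound 1 to compound 4 is expected to be small, most likely within the scatter, with a slight lean downward. Compound 4 is thus estimated at 86%, in a range from 66% to 98%, the step of a number 6 percentage points lower from compound 1 to compound 4 (within the scatter) being the expected outcome.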

Compound 4, a percentage reported as inhibition, in the whole organism at one dose (the size of the read-out at that dose, not a potency): 60%
Compound 4: middle estimate off by 26 percentage points, on the high side; measured number below the stated range.
By their numbers in this assay, from the lowest: compounds 3 and 4 (each within the scatter of the next); then compounds 1 and 2 (each within the scatter of the next).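

In this assay, amino in place of methyl on this aromatic carbon is a large change (a number 32 percentage points lower from compound 1 to compound 4 (beyond the scatter)). For the compounds shown here, this is the first single-place step among the compounds, and it shows that this carbon of the five-membered aromatic ring, next to the ring nitrogen, is not indifferent to the group it bears: exchanging one heavy atom for another, with one hydrogen-bond donor and one hydrogen-bond acceptor entering, moves the read-out beyond the scatter. Nothing measured here explains the drop.

The compounds shown leave open whether the drop is tied to the amino group itself or would follow other replacements of the methyl, a question that a hydrogen, a hydroxyl or a methylamino group on the same carbon would bear on. They also leave open whether the same change would have a similar effect on a different core.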